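This account rests on a few compounds, and the source may have more. Where it says the series, first, only, none or still open, it means among the compounds named here.

Compound 1 `Nc1cc(N)c2nc(-c3ccccc3)c(Oc3ccc(Cl)c(Cl)c3)nc2c1` carries a 3,4-dichlorophenoxy group on its core. Within the data shown here, in a functional assay on CAKI-1 cells (Homo sapiens) for inhibition, read by sulforhodamine B assay, with a stated time of 48 h (on this read-out lower numbers stand for stronger inhibition of growth and higher numbers for weaker inhibition of growth), compound 1 gives 15800 nM, the lower of the two numbers measured so far. Compound 2 `CCOC(=O)[C@H](CCC(=O)O)NC(=O)c1ccc(Sc2nc3cc(N)cc(N)c3nc2-c2ccccc2)cc1`, built on a related core but with a different and larger group attached to it, gives 79400 nM in this assay; the gap between these two values lies beyond the usual scatter, so compound 1 inhibits growth more strongly. Compound 3 `Nc1cc(N)c2nc(-c3ccccc3)c(Oc3ccc(F)cc3)nc2c1` has not yet been measured. It differs from compound 1 in one place: 4-fluorophenyl in place of 3,4-dichlorophenyl on an oxygen on an aromatic ring. Among the measured compounds shown here, no pair of measured compounds shows this kind of change, so there is no direct guide to its effect. A modest step toward weaker inhibition seems plausible, and the expected step is a 1.6-fold higher number from compound 1 to compound 3 (0.20 log units; within the scatter). Compound 3 is therefore estimated at 25000 nM, with a likely range from 8000 nM to 80000 nM.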

Compound 3, concentration for 50% growth inhibition: 11200 nM
For compound 3 the middle estimate is 2.2-fold (0.35 log units) above the measured one; the range from low to high includes it.
By their numbers in this assay, from the lowest: compounds 3 and 1 (each within the scatter of the next); then compound 2.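

In this assay, among these compounds, the exchange of 3,4-dichlorophenyl for 4-fluorophenyl on the oxygen gives a 1.4-fold lower number from compound 1 to compound 3 (0.15 log units; within the scatter) and is the first direct reading at this position. The read-out does not separate the two groups, so losing both chlorine atoms and gaining one fluorine is tolerated here, at least for this one pair of halogen-bearing rings. No measurement at hand explains why the two groups read alike.

Both groups shown are halogen-bearing phenyl rings, so it remains open whether the halogens matter at all, or whether a plain phenyl, a methoxy-bearing phenyl or a phenyl carrying a dimethylaminoethyl chain would read the same. Going by these compounds, it is also open whether a sulfur in place of the oxygen would change the number on this core.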